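Removing the Hydroxy Group of Compound 1

The source may hold more compounds than are shown below. What is called first, only, known or untested is meant among the compounds shown, and "the series" means these compounds.

Compound 1 `Oc1cccc(-c2ccc3c(-c4cncnc4)c(O)ccc3c2)c1` stands highest of the three compounds measured in an assay for binding affinity to 17-beta-hydroxysteroid dehydrogenase type 2 (Homo sapiens), read by scintillation counting, with a stated time of 10 min, tested at 1 uM; a higher number here means more inhibition at the concentration tested (going by the name of the read-out), a lower number less inhibition: compound 1 gives 85%. Its nearest neighbour, compound 2 `Oc1cccc(-c2ccc3c(-c4ccc5[nH]ccc5c4)c(O)ccc3c2)c1`, gives 19%, and compound 3 `COc1ncc(-c2c(O)ccc3cc(-c4cccc(O)c4)ccc23)c(OC)n1` gives 9%. Both gaps are beyond the scatter. Within the data shown here, the only step measured between two compounds that differ in one place is a number 66 percentage points lower from compound 1 to compound 2 (beyond the scatter), and it concerns the exchange of the pyrimidin-5-yl group, not the hydroxy group.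

Compound 4 `Oc1cccc(-c2ccc3c(-c4cncnc4)cccc3c2)c1` differs from compound 1 in one place: hydrogen in place of hydroxy on an aromatic carbon. Among the measured compounds shown here, no measured step bears on this hydroxy group, so the measured data give no size for the change; the step from compound 1 to compound 2 only shows that a single change on this core can move the read-out a great deal. Starting from compound 1, which gives 85%, a downward step is expected, estimated at a number 35 percentage points lower from compound 1 to compound 4 (beyond the scatter). Compound 4 is therefore expected to give about 50%, within a range from 15% to 85%.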

Compound 4, a percentage reported as inhibition, at one concentration (the size of the read-out at that concentration, not a potency): < 10%
Compound 4 ended at the assay's limit; the forecaster's own chance of this, stated with the estimate: 0%; at least 40 percentage points between middle value and limit.
By their numbers in this assay, from the lowest: compounds 3 and 2 (each within the scatter of the next); then compound 1.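

The hydroxy group on the shared core carries much of the read-out in this assay: replacing it with hydrogen gives a number at least 75 percentage points lower from compound 1 to compound 4 (beyond the scatter). Compound 4 stands at a limit of the assay and not at a number: the limit of < 10% in this assay, at which 1 of the 4 values shown sits. Among these compounds, the only earlier step concerned the pyrimidin-5-yl group, whereas this one shows that the neighbouring ring position, ortho to that group, also counts and that the pyrimidin-5-yl group alone does not keep the read-out at the level of compound 1.

Hydrogen is the only replacement shown here, so what an amine or a fluorine atom would give at this position stays open. As far as these compounds go, whether the same exchange would cost as much with the 1H-indol-5-yl group of compound 2 in place of pyrimidin-5-yl also stays open.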